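The source may hold more compounds than are shown below. What is called first, only, known or untested is meant among the compounds shown, and "the series" means these compounds.

For the measured compounds named here, in a functional assay on A549 cells (Homo sapiens) for antiproliferative activity, read by MTT assay, with a stated time of 72 h (a lower number here means a stronger inhibitor, a higher number a weaker inhibitor), compound 1 `CNC(=O)c1cc(Oc2ccc(NC(=O)c3cc4cccnc4n(-c4ccccc4F)c3=O)cc2)ccn1` gives 610 nM, the lowest of the three numbers measured so far. Compound 2 `CNC(=O)c1cc(Oc2ccc(NC(=O)c3cc4cccnc4n(-c4ccc(Br)cc4F)c3=O)cc2)ccn1` gives 1420 nM and compound 3 `CNC(=O)c1cc(Oc2ccc(NC(=O)c3cc4cccnc4n(-c4ccc(C(F)(F)F)cc4Cl)c3=O)cc2)ccn1` gives 2090 nM. The steps of a 2.3-fold higher number from compound 1 to compound 2 (0.37 log units; beyond the scatter) and a 3.4-fold higher number from compound 1 to compound 3 (0.53 log units; beyond the scatter) both lie beyond the scatter, while a 1.5-fold higher number from compound 2 to compound 3 (0.17 log units; within the scatter) does not. All three of those steps alter the aromatic ring attached to the ring nitrogen of the shared core. Compound 4 `CCCNC(=O)c1cc(Oc2ccc(NC(=O)c3cc4cccnc4n(-c4ccccc4F)c3=O)cc2)ccn1` differs from compound 1 at a different place: ethyl in place of hydrogen on a saturated chain carbon bound to an amide-type nitrogen. Going by the values given here, no measured step touches this part of the molecule, so the measurements give no direct guide for it. The expectation is therefore a step of a 1.1-fold higher number from compound 1 to compound 4 (0.06 log units; within the scatter) that stays within the scatter. Compound 4 is estimated at 700 nM in this assay, with a range from 300 nM to 1600 nM.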

Compound 4, half-maximal inhibitory concentration: 150 nM
Beside the measured number, compound 4's estimate is 4.7-fold (0.67 log units) above it, and the stated range ends above it.
By their numbers in this assay, from the lowest: compound 4; then compound 1; then compounds 2 and 3 (each within the scatter of the next).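

In this assay, for the compounds shown here, the change from methylcarbamoyl to propylcarbamoyl gives a 4.1-fold lower number from compound 1 to compound 4 (0.61 log units; beyond the scatter) and so shows that this amide chain, untouched by the earlier steps, does affect the result. It is also the first step from compound 1 that lowers the number, whereas both earlier steps from compound 1 raised it. No measured property of these compounds accounts for the change.

As far as these compounds go, whether a longer chain such as butyl, or a branched one such as isopropyl, would lower the number further remains open. So does whether propylcarbamoyl would act the same way alongside the 4-bromo-2-fluorophenyl group of compound 2.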